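Swapping allyl for 4-iodophenyl: an expected step down

The compounds below may be only part of what the source reports. "The series", "measured", "known", "first", "only" and "open" are said of these compounds alone.

- Compound 1 `C=CCNC(=S)N/N=C1\C(=O)Nc2ccc([N+](=O)[O-])cc21`: 50%
- Compound 2 `O=C1Nc2ccc([N+](=O)[O-])cc2/C1=N/NC(=S)Nc1ccc(F)cc1`: 20%

In a functional assay on the whole organism for inhibition, with Lemna aequinoctialis as the target, tested at 1000 ug/mL (a lower number here means less inhibition of growth, a higher number more inhibition of growth at the concentration tested), compound 1 at 50% is the higher of the two measured compounds. The change leading to compound 3 `O=C1Nc2ccc([N+](=O)[O-])cc2/C1=N/NC(=S)Nc1ccc(I)cc1`, which has not yet been measured, is 4-iodophenyl in place of allyl on an amide-type nitrogen. Going by the values given here, the one measured step bearing on it is a number 30 percentage points lower from compound 1 to compound 2 (beyond the scatter) with 4-fluorophenyl as the incoming group, a modest drop beyond the scatter. A downward step of similar size is therefore expected in this assay for this change. The estimate amounts to a number 30 percentage points lower from compound 1 to compound 3 (beyond the scatter) as the expected step. For compound 3 the expected value is 20% with 5% to 40% as the estimated range.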

Compound 3, percent growth inhibition at one concentration: 25%
Beside the measured number, compound 3's estimate is 5 percentage points below it; low and high end bracket the measured number.
By their numbers in this assay, from the lowest: compounds 2 and 3 (each within the scatter of the next); then compound 1.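

In this assay, 4-iodophenyl on the amide-type nitrogen gives a number 25 percentage points lower from compound 1 to compound 3 (beyond the scatter) and so repeats the loss seen with 4-fluorophenyl. Iodo in place of fluoro on the aromatic carbon gives a number 5 percentage points higher from compound 2 to compound 3 (within the scatter) and does not separate the two halogens, so both aryl compounds stand apart from the allyl compound 1 by a similar margin. No evidence available here explains this drop. The compounds shown leave open whether an unsubstituted phenyl would sit with these two halogenated compounds. They also leave open whether a propyl chain or a longer chain would stay near compound 1.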